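The source may report more compounds than this note shows. Statements on the series, on what has been measured and on what is new or still open speak of the compounds shown alone.

Measured so far:
compound 1 `O=C(Nc1cccc(-n2cc(-c3ccncc3)c(-c3ccc(Cl)c(O)c3)n2)c1)Nc1cccc(C(F)(F)F)c1` gives 7350 nM
compound 2 `COc1cc(-c2nn(-c3cccc(NC(=O)c4cccc(C(F)(F)F)c4)c3)cc2-c2ccncc2)ccc1Cl` gives 1660 nM

In a functional assay on NCI-H226 cells (Homo sapiens) for inhibition, read by sulforhodamine B assay, with a stated time of 48 h (a lower number here means a stronger inhibitor of growth, a higher number a weaker inhibitor of growth), compound 2 stands at the lowest of the two numbers; the nearest, compound 1, sits at a higher number beyond the scatter. Compound 3 `COc1cc(-c2nn(-c3cccc(NC(=O)c4ccc(Cl)c(C(F)(F)F)c4)c3)cc2-c2ccncc2)ccc1Cl` differs from compound 2 by chloro in place of hydrogen on an aromatic carbon. Among the compounds with values here, no step between measured compounds bears on this change, so the expectation rests on compound 2 alone. In this assay a small move toward a lower number is expected, possibly no larger than the scatter. Compound 3 is estimated at 1000 nM, between 300 nM and 4000 nM. The step this estimate means is expected to be a 1.7-fold lower number from compound 2 to compound 3 (0.22 log units; within the scatter).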

Compound 3, concentration for 50% growth inhibition: 5900 nM
Compound 3: the middle estimate sits 5.9-fold (0.77 log units) below what was measured, and the stated range ends below it.
By their numbers in this assay, from the lowest: compound 2; then compounds 3 and 1 (each within the scatter of the next).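

In this assay, chloro in place of hydrogen on this aromatic carbon, ortho to a trifluoromethyl group, gives a 3.6-fold higher number from compound 2 to compound 3 (0.55 log units; beyond the scatter). Within the data shown here, this is the first step, and it shows that growth inhibition responds to a single added atom at this position, in the weakening direction. Nothing measured here accounts for the loss. From the compounds shown here alone, whether it is particular to chloro remains open, since fluoro, methyl or methoxy on the same carbon would test this. The effect of the same chloro with the urea linker of compound 1 is also unknown.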